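From 4-Chlorophenyl to 3-Chlorophenyl: A Half-Life Estimate

The source may hold more compounds than are shown below. What is called first, only, known or untested is meant among the compounds shown, and "the series" means these compounds.

Of the compounds shown here, three have so far been measured in an in vivo ADME assay on the whole organism (Cavia porcellus); on this read-out lower numbers stand for a shorter-lived compound and higher numbers for a longer-lived compound. Compound 1 `CCC(NC(=O)c1ccc(C(=N)N)cc1)C(C)(C)C(=O)N1CCC(CC(=O)O)CC1` gives 1.3 h, compound 2 `CCCC(NC(=O)c1ccc(C(=N)N)cc1)C(C)(C)C(=O)N1CCC(CC(=O)O)CC1` gives 0.9 h, and compound 3 `CC(C)(C(=O)N1CCC(CC(=O)O)CC1)C(NC(=O)c1ccc(C(=N)N)cc1)c1ccc(Cl)cc1` gives 1.2 h. Compound 3 stands together with the other two, with nothing separating them beyond the scatter. Its two steps are a 1.1-fold lower number from compound 1 to compound 3 (0.03 log units; within the scatter) and a 1.3-fold higher number from compound 2 to compound 3 (0.12 log units; within the scatter).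

Compound 4 `CC(C)(C(=O)N1CCC(CC(=O)O)CC1)C(NC(=O)c1ccc(C(=N)N)cc1)c1cccc(Cl)c1` differs from compound 3 in one place, with 3-chlorophenyl in place of 4-chlorophenyl on a saturated chain carbon bound to an amide-type nitrogen and a saturated chain carbon. Going by the values given here, no measured pair makes this exact exchange, so the evidence is indirect. At the same carbon, the two steps already given replace an ethyl or a propyl with 4-chlorophenyl, and neither goes beyond the scatter. The remaining step, a methyl in place of hydrogen on the chain, is a 1.4-fold lower number from compound 1 to compound 2 (0.16 log units; within the scatter), and it also stays within the scatter. On these three compounds, no step beyond the scatter is expected in this assay, and no direction can be favoured. The estimated step is a 1.1-fold lower number from compound 3 to compound 4 (0.04 log units; within the scatter). The expected half-life of compound 4 is 1.1 h, with an estimated range from 0.7 h to 1.8 h.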

Compound 4, half-life: 2.5 h
Estimate against measurement, compound 4: 2.3-fold (0.36 log units) below, and the stated range ends below it.
By their numbers in this assay, from the lowest: compounds 2, 3, 1 and 4 (each within the scatter of the next, the first and the last beyond it).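

Going by these compounds alone, exchanging 4-chlorophenyl for 3-chlorophenyl on the saturated chain carbon bound to an amide-type nitrogen and a saturated chain carbon gives a 2.1-fold higher number from compound 3 to compound 4 (0.32 log units; beyond the scatter) in this assay, whereas every step among the earlier compounds stayed within the scatter; at this position, then, the half-life responds to where the chlorine sits on the phenyl ring, even though the 4-chlorophenyl group had stood level with both alkyl chains. Set against those chains, 3-chlorophenyl in place of propyl gives a 2.8-fold higher number from compound 2 to compound 4 (0.44 log units; beyond the scatter), while 3-chlorophenyl in place of ethyl gives a 1.9-fold higher number from compound 1 to compound 4 (0.28 log units; within the scatter), so the gain over the alkyl groups is clear for propyl but not for ethyl. Nothing available here accounts for the shift in half-life that this exchange produces.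

The compounds shown leave open whether the chlorine itself matters at this ring position, since neither an unsubstituted phenyl nor a 3-fluorophenyl or 3-methoxyphenyl group stands among them. They also leave open how a 2-chlorophenyl group would compare with the two chlorophenyl groups on the same carbon.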